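Closing the gap from benzylamino to butylamino

This account rests on a few compounds, and the source may have more. Where it says the series, first, only, none or still open, it means among the compounds named here.

Compound 1, `CCCCSc1nc(N)nc2c1ncn2/C=C1/CC1(CO)CO`, gives 89000 nM in an ADME assay on CCRF-HSB-2 cells (Homo sapiens) for cytotoxicity, with a stated time of 7 days; a lower number here means that less compound is tolerated, a higher number that more compound is tolerated. Compound 2, `CCCNc1nc(N)nc2c1ncn2/C=C1/CC1(CO)CO`, reaches only the limit > 20000 nM in this assay. Compound 3, `Nc1nc(NCc2ccccc2)c2ncn(/C=C3/CC3(CO)CO)c2n1`, also reaches only the limit > 20000 nM in this assay.

Compound 3 therefore stands at the limit, as does one other value shown (the limit of > 20000 nM in this assay, at which 2 of the 3 values shown sit), so nothing within the three compounds can be ranked; the steps a step that the limit leaves unreadable from compound 1 to compound 2, a step that the limit leaves unreadable from compound 1 to compound 3 and a step that the two limits leave unreadable from compound 2 to compound 3 are all unreadable. Compound 4, `CCCCNc1nc(N)nc2c1ncn2/C=C1/CC1(CO)CO`, differs from compound 3 by propyl in place of phenyl on a saturated chain carbon bound to a nitrogen on an aromatic ring, benzylamino to butylamino. With every relevant step unreadable, no direction can be taken from them; compound 1 shows that a nearby chain is tolerated at a high concentration. The step that the limit leaves unreadable from compound 3 to compound 4 is expected to be small, and compound 4 is estimated at 60000 nM, between 20000 nM and 200000 nM.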

Compound 4, half-maximal cytotoxic concentration: > 20000 nM
Compound 4: a limit, no number; the forecaster's own chance of this, stated with the estimate: 70%; the middle value lies beyond the limit too.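

Compound 4 also gives only a limit, so no step linking it to compound 1, compound 2 or compound 3 can be read: the limit of > 20000 nM in this assay, at which 3 of the 4 values shown sit.

From the compounds shown here alone, how compound 2, compound 3 and compound 4 rank against one another or against compound 1 in this assay remains open.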